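Swapping the ring on the piperazine nitrogen of a benzamide

The compounds below may be only part of what the source reports. "The series", "measured", "known", "first", "only" and "open" are said of these compounds alone.

Compound 2 has the structure `Nc1ccccc1NC(=O)c1ccc(CSC(=S)N2CCN(c3ccc(F)cc3)CC2)cc1`. Going by the values given here, in a functional assay on HeLa cells (Homo sapiens) for antiproliferative activity, read by CCK-8 assay, with a stated time of 72 h, tested at 8 uM (a higher number here means a stronger effect of the compound at the concentration tested, a lower number a weaker effect), compound 2 gives 64.5%, the only other compound measured being compound 1 with the structure `Nc1ccccc1NC(=O)c1ccc(CSC(=S)N2CCN(c3cccnc3)CC2)cc1`, which in this assay gives 72.5%. Among the compounds with values here, the one measured step, a number 8 percentage points lower from compound 1 to compound 2 (within the scatter), stays within the scatter, so the two numbers cannot be ranked against each other.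

Compound 3 has the structure `Nc1ccccc1NC(=O)c1ccc(CSC(=S)N2CCN(Cc3ccncc3)CC2)cc1`. It differs from compound 2 at the same place where compound 2 differs from compound 1: (pyridin-4-yl)methyl in place of 4-fluorophenyl on an amine nitrogen in a ring.

Within the data shown here, the only step that bears on this change is a number 8 percentage points lower from compound 1 to compound 2 (within the scatter), which shows that exchanging the ring on this amine nitrogen between a pyridinyl and a fluorophenyl group left the read-out essentially unchanged. Nothing measured here speaks for a larger effect of placing a methylene between that nitrogen and a pyridine ring. Compound 3 is therefore expected to show a step of a number 3.5 percentage points higher from compound 2 to compound 3 (within the scatter), which would not exceed the scatter. For compound 3 the estimate in this assay is 68%, with a range from 50% to 82%.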

Compound 3, a percentage reported as inhibition, at one concentration (the size of the read-out at that concentration, not a potency): 72.9%
Compound 3: middle estimate off by 4.9 percentage points, on the low side; the measured number falls inside the stated range.
By their numbers in this assay, from the lowest: compounds 2, 1 and 3 (each within the scatter of the next).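

With compound 3, the amine nitrogen in the ring now carries a pyridine ring on a methylene as well as directly attached rings, and this assay does not separate these forms: a number 8.4 percentage points higher from compound 2 to compound 3 (within the scatter) and a number 0.4 percentage points higher from compound 1 to compound 3 (within the scatter), both steps staying inside the usual scatter. Going by these compounds alone, the earlier pair had compared only two rings attached directly to that nitrogen, whereas these steps extend the comparison to a group with the same count of heavy atoms as 4-fluorophenyl, but with a ring nitrogen and a hydrogen-bond acceptor in place of the fluorine-bearing ring, and the three compounds still cannot be ranked. The data offer no measured account of why this position accommodates such exchanges without a readable difference in the read-out.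

As far as these compounds go, what remains open is whether a longer chain such as 2-(pyridin-4-yl)ethyl, a small alkyl group such as methyl, or a carboxylic acid on this nitrogen would move the read-out beyond the scatter. The read-out comes from a single concentration, so it also leaves open whether compound 1, compound 2 and compound 3 would show a stronger or weaker effect than one another at other concentrations.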